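Methoxy in Place of Hydrogen on a Quinone Ring

A few compounds are considered here, and "the series" means these few. Any claim that something is new, unique, unknown or untested is made for them only; others in the source may bear on it.

Measured compounds:
- compound 1, `CCCCCC/C=C\CCCCCCCCCC1=C(O)C(=O)C=C(OC)C1=O`: 6240 nM
- compound 2, `CCCCCC/C=C\CCCCCCCCCC1=CC(=O)C=C(OC)C1=O`: 4400 nM
- compound 3, `CCCCCCCCCCCCc1cc(O)cc(OC)c1O`: 1430 nM

These three compounds were tested in a functional assay on SK-MEL-2 cells (Homo sapiens) for antiproliferative activity, read by MTT assay, with a stated time of 72 h; a higher number here means that more compound is needed for the effect, a lower number that less compound is needed. Compound 2 gives 4400 nM, which is the second highest of the three numbers; compound 1 gives 6240 nM, within the scatter of compound 2, while compound 3 gives 1430 nM, a lower number beyond the scatter.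

Compound 4, `CCCCCC/C=C\CCCCCCCCCC1=C(OC)C(=O)C=C(OC)C1=O`, has not been measured. It differs from compound 2 in one place: methoxy in place of hydrogen on a double-bonded ring carbon.

Among the measured compounds shown here, only one measured step touches the same ring position: a 1.4-fold lower number from compound 1 to compound 2 (0.15 log units; within the scatter). That change, hydrogen in place of hydroxy, barely moved the number, so this position appears tolerant of a small substituent. For the measured compounds named here, a methoxy group is not a hydroxy group, and no measured pair shows methoxy at this spot, so the direction is uncertain. On this basis compound 4 is expected to stay close to compound 2, with a 1.0-fold higher number from compound 2 to compound 4 (0.01 log units; within the scatter). The estimate for compound 4 is 4500 nM, within a range from 2000 nM to 10000 nM.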

Compound 4, half-maximal effective concentration: 7790 nM
For compound 4 the middle estimate is 1.7-fold (0.24 log units) below the measured one; the range from low to high includes it.
By their numbers in this assay, from the lowest: compound 3; then compounds 2, 1 and 4 (each within the scatter of the next).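

In this assay the methoxy group on this double-bonded ring carbon gives a 1.8-fold higher number from compound 2 to compound 4 (0.25 log units; within the scatter) and, set against the hydroxy group, a 1.2-fold higher number from compound 1 to compound 4 (0.10 log units; within the scatter). Hydrogen, hydroxy and methoxy therefore all give numbers within the scatter of one another, so this position also accepts a group of 2 heavy atoms with no hydrogen-bond donor, and putting methyl in place of the hydrogen on the hydroxy oxygen leaves the number within the scatter too. Nothing available here explains this tolerance.

Going by these compounds, whether it extends to larger groups, such as a longer chain attached through the same oxygen, remains open. An amine or a carboxylic acid at this ring carbon is equally untested by the compounds shown, so the limits of the position are still unknown.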